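Bromo to chloro on the phenoxy end

This account rests on a few compounds, and the source may have more. Where it says the series, first, only, none or still open, it means among the compounds named here.

Values in a functional assay on HL-60 cells (Homo sapiens) for antiproliferative activity, read by MTT assay, with a stated time of 72 h; on this read-out higher numbers stand for weaker inhibition and lower numbers for stronger inhibition:
- compound 1 `NC1=NC2(CCSCC2)N(OCCCOc2cccc(Cl)c2Cl)C(N)=N1`: 30 nM
- compound 2 `NC1=NC2(CCSCC2)N(OCCCOc2cc(Cl)c(Cl)cc2Cl)C(N)=N1`: 730 nM
- compound 3 `NC1=NC2(CCSCC2)N(OCCCOc2ccccc2Br)C(N)=N1`: 180 nM

Compound 3, at 180 nM, is second highest of the three numbers. The next structure is compound 4 `NC1=NC2(CCSCC2)N(OCCCOc2ccccc2Cl)C(N)=N1`: chloro in place of bromo on an aromatic carbon, ortho to a large group. Going by the values given here, two measured steps bear on it, a 6.0-fold higher number from compound 1 to compound 3 (0.78 log units; beyond the scatter) and a 4.1-fold lower number from compound 2 to compound 3 (0.61 log units; beyond the scatter), both modest. Each exchanges more of the ring substitution than this single swap, and neither is a direct bromo-to-chloro comparison. No step beyond the scatter is therefore expected in this assay, and the expected step is a 1.1-fold lower number from compound 3 to compound 4 (0.05 log units; within the scatter). For compound 4 the estimate is 160 nM, with an expected range of 70 nM to 370 nM.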

Compound 4, half-maximal inhibitory concentration: 390 nM
Beside the measured number, compound 4's estimate is 2.4-fold (0.39 log units) below it; measured number outside the range, above it.
By their numbers in this assay, from the lowest: compound 1; then compound 3; then compounds 4 and 2 (each within the scatter of the next).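

In this assay, going by these compounds alone, this position does distinguish the two halogens: chloro in place of bromo gives a 2.2-fold higher number from compound 3 to compound 4 (0.34 log units; beyond the scatter), the first direct reading of this exchange. Hydrogen in place of the other chloro costs far more, with a 13-fold higher number from compound 1 to compound 4 (1.11 log units; beyond the scatter), while a 1.9-fold lower number from compound 2 to compound 4 (0.27 log units; within the scatter) shows that 2-chlorophenyl and 2,4,5-trichlorophenyl are not separated here, so the number of chloro groups alone does not set the value. No evidence at hand explains either difference. Still open, as far as these compounds go, is how a fluoro or a methoxy on this aromatic carbon would read, and whether the bromo-to-chloro step holds with a longer chain.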